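Nitrophenyl in place of difluorophenyl on the shared core

The source may report more compounds than this note shows. Statements on the series, on what has been measured and on what is new or still open speak of the compounds shown alone.

Compound 1 `COc1cc(-c2ccc3ncn(-c4cc(OC)c(OC)c(OC)c4)c3c2)cc(OC)c1OC` gives in a functional assay on SGC-7901 cells (Homo sapiens) for antiproliferative activity, read by MTT assay, with a stated time of 72 h (on this read-out higher numbers stand for weaker inhibition and lower numbers for stronger inhibition), only a limit, > 10000 nM, and that reading is the limit of > 10000 nM in this assay, at which 1 of the 2 values shown sits. Among the compounds with values here, compound 2 `COc1cc(-n2cnc3ccc(-c4cc(F)ccc4F)cc32)cc(OC)c1OC` is the one compound of the pair with a number: in this assay compound 2 gives 6590 nM. Within the data shown here, no step between two measured compounds is available, so no measured change guides the next move. Compound 3 `COc1cc(-n2cnc3ccc(-c4cccc([N+](=O)[O-])c4)cc32)cc(OC)c1OC` is not yet measured; it carries 3-nitrophenyl in place of 2,5-difluorophenyl on an aromatic carbon. With nothing measured on a change of this kind, the expectation is a step no larger than the usual scatter, in either direction, and a 1.1-fold higher number from compound 2 to compound 3 (0.03 log units; within the scatter) is what the estimate means. Compound 3 is therefore expected to give about 7000 nM in this assay, within 2500 nM to 20000 nM. Since compound 2 already sits close to the limit, a reading of only a limit for compound 3 is a real possibility.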

Compound 3, half-maximal inhibitory concentration: 380 nM
Estimate against measurement, compound 3: 18-fold (1.27 log units) above, outside the stated range (below it).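

In this assay, the aromatic carbon carrying the aryl group on the shared core proves sensitive to what it bears: the change to 3-nitrophenyl gives a 17-fold lower number from compound 2 to compound 3 (1.24 log units; beyond the scatter). The earlier compounds shown here offered one number and one limit with no step between them, so they could not show this. The two groups differ both in their substituents and in where these sit on the phenyl ring, so this single step cannot separate the two, and nothing shown gives a cause for it.

Open, going by these compounds, is whether the step follows the nitro group itself or its place on the ring. Also open, on these data alone, is whether an amine or a nitrile on the same phenyl ring, or an unsubstituted phenyl, would read like compound 3 or like compound 2.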